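Phenyl for 2-Fluorobenzyl on a Piperazine Nitrogen

The source may hold more compounds than are shown below. What is called first, only, known or untested is meant among the compounds shown, and "the series" means these compounds.

Compound 1, `COc1ccc(-c2cnc3nc(N)nc(N4CCN(Cc5ccccc5F)CC4)c3n2)cc1OC`, gives 700 nM in a functional assay on cells (T-cell, Homo sapiens) for inhibition; a lower number here means a stronger inhibitor, a higher number a weaker inhibitor.
Compound 2, `Cc1ccc(-c2cnc3nc(N)nc(OC(C)C)c3n2)cc1C`, gives 10000 nM in this assay.

Compound 1 stands lowest of the two numbers; compound 2 lies above it by a gap beyond the usual scatter, so compound 1 is the stronger inhibitor of the pair. Compound 3, `COc1ccc(-c2cnc3nc(N)nc(N4CCN(c5ccccc5)CC4)c3n2)cc1OC`, has not yet been measured. It differs from compound 1 in one place: phenyl in place of 2-fluorobenzyl on an amine nitrogen in a ring. Among the compounds with values here, no step between two measured compounds shows what such a change does here, since compound 2 differs from compound 1 in several places at once. For compound 3 a small step is expected in this assay, at most a modest weakening, which may well fall within the scatter, so that the estimated step of a 1.4-fold higher number from compound 1 to compound 3 (0.15 log units; within the scatter) is slight. Compound 3 is expected to give about 1000 nM, within a range of 300 nM to 3500 nM.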

Compound 3, half-maximal inhibitory concentration: 400 nM
The estimate for compound 3 lay 2.5-fold (0.40 log units) above the measured number; measured number inside the range.
By their numbers in this assay, from the lowest: compounds 3 and 1 (each within the scatter of the next); then compound 2.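

In this assay the first step read at this position is a 1.8-fold lower number from compound 1 to compound 3 (0.24 log units; within the scatter), so phenyl in place of 2-fluorobenzyl on an amine nitrogen in a ring leaves compound 1 and compound 3 indistinguishable. On this single pair, the aromatic ring on that nitrogen can be carried with or without the fluorine and the carbon that links it to the ring, and activity stays in the same range. Nothing on hand explains this result.

Open, from the compounds shown here alone, is what a bare hydrogen, a carboxylic acid or a longer chain ending in an amine would do on that same nitrogen, since both groups seen there carry a six-membered aromatic ring of carbon only. Going by these compounds, the contribution of the ring amine itself also remains open, as compound 2 differs from compound 1 in several places at once.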